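The source may report more compounds than this note shows. Statements on the series, on what has been measured and on what is new or still open speak of the compounds shown alone.

Compound 1 `Cc1c(OCCCCOc2ccc(C(=O)O)cc2Cl)ccc(C(=O)CC2CCCC2)c1O`: 237 nM
Compound 2 `Cc1c(OCCCCOc2ccc(C(=O)CC(C)(C)C)c(O)c2C)cccc1C(=O)O`: 136 nM
Compound 3 `CCCC(=O)c1ccc(OCCCCOc2ccc(C(=O)O)cc2C)c(C)c1O`: 104 nM

These three compounds were measured in an assay on HEK293 cells for positive allosteric modulation of metabotropic glutamate receptor 2 (Rattus norvegicus), read by thallium flux, with a stated time of 2.5 min; on this read-out higher numbers stand for an effect only at larger amounts of compound and lower numbers for an effect already at smaller amounts. Compound 1 has the highest of the three numbers; compound 2 lies within the scatter of it, while compound 3 lies beyond the scatter with a lower number. Compound 4 `Cc1cc(OCCCCOc2ccc(C(=O)CC3CCCC3)c(O)c2C)ccc1C(=O)O` has not yet been measured. It differs from compound 1 in one place: 4-carboxy-3-methylphenyl in place of 4-carboxy-2-chlorophenyl on an oxygen on a saturated carbon. Among the compounds with values here, no pair of measured compounds shows this change, so the expectation for compound 4 in this assay rests on compound 1 alone and on the spread of the other values. A small step toward a lower number, not clearly beyond the scatter, is expected, a 1.3-fold lower number from compound 1 to compound 4 (0.12 log units; within the scatter). For compound 4 the estimate in this assay is 180 nM, within 80 nM to 400 nM.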

Compound 4, half-maximal effective concentration: 564 nM
Estimate against measurement, compound 4: 3.1-fold (0.50 log units) below, and the stated range ends below it.
By their numbers in this assay, from the lowest: compounds 3, 2 and 1 (each within the scatter of the next, the first and the last beyond it); then compound 4.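

In this assay, placing 4-carboxy-3-methylphenyl in place of 4-carboxy-2-chlorophenyl on an oxygen on a saturated carbon gives a 2.4-fold higher number from compound 1 to compound 4 (0.38 log units; beyond the scatter). Within the data shown here, this is the first comparison here that differs in one place, and it shows that the two groups are not interchangeable at this position, with a modest step beyond the scatter. Nothing available explains this step.

The step changes both the substituent and its numbered place on the ring, leaving their separate contributions unresolved. On these data alone, how a fluorine or a methoxy group would compare at this position also remains open.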